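The compounds below may be only part of what the source reports. "The series", "measured", "known", "first", "only" and "open" are said of these compounds alone.

The compounds measured so far in an assay on isolated protein for inhibition of Indoleamine 2,3-dioxygenase 1 (Homo sapiens), with a stated time of 30 min; on this read-out lower numbers stand for stronger inhibition and higher numbers for weaker inhibition:

Compound 1, `CCOC(=O)c1cnc2scc(-c3ccc(CC)cc3)n12`, gives 24000 nM.
Compound 2, `CCOC(=O)c1cnc2scc(-c3ccccc3)n12`, gives > 100000 nM, which is a limit of the assay and not a number.

Compound 2 therefore stands at the weak end of the two values shown, at the limit of > 100000 nM in this assay, at which 1 of the 2 values shown sits. Among the measured compounds shown here, only one measured step bears on the question: an at least 4.1-fold higher number from compound 1 to compound 2 (0.61 log units; beyond the scatter), where an ethyl group on the six-membered ring was taken away. Compound 3, `CCOC(=O)c1cnc2scc(-c3ccccc3C)n12`, goes the other way from compound 2, but at a different spot: methyl in place of hydrogen on an aromatic carbon, on an aromatic carbon of a six-membered aromatic ring of carbon only, ortho to a large group. For the measured compounds named here, no measured pair shows the effect of a group at this place, and the removed ethyl of compound 1 sat elsewhere on the ring, so the one known step is only a loose guide. A small gain in this assay is expected, but compound 3 may well remain at the limit. The expected step is an at least 1.2-fold lower number from compound 2 to compound 3 (0.09 log units; that floor lies within the scatter), and the estimate for compound 3 is 80000 nM, within 20000 nM to 300000 nM.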

Compound 3, half-maximal inhibitory concentration: > 100000 nM
Compound 3 ended at the assay's limit; the forecaster's own chance of this, stated with the estimate: 55%; middle value at least 1.2-fold (0.09 log units) away from the limit.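

In this assay, compound 2 and compound 3 both stop at a limit of the assay and not at a number, so the step from hydrogen to methyl cannot be read: the limit of > 100000 nM in this assay, at which 2 of the 3 values shown sit. The compounds shown leave open whether a methyl group at this place changes the inhibition at all.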